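The source may report more compounds than this note shows. Statements on the series, on what has been measured and on what is new or still open speak of the compounds shown alone.

Measured so far in a functional assay on A549 cells (Homo sapiens) for antiproliferative activity, read by MTT assay, with a stated time of 72 h; on this read-out higher numbers stand for weaker inhibition and lower numbers for stronger inhibition: compound 1 `COc1cc(-c2ccc3ncn(-c4cc(OC)c(OC)c(OC)c4)c3c2)cc(OC)c1OC` gives > 10000 nM, which is a limit of the assay rather than a number, namely (the limit of > 10000 nM in this assay, at which 1 of the 3 values shown sits). Compound 2 `COc1ccccc1-c1ccc2ncn(-c3cc(OC)c(OC)c(OC)c3)c2c1` gives 4320 nM. Compound 3 `COc1cc(-n2cnc3ccc(-c4ccccc4)cc32)cc(OC)c1OC` gives 3060 nM.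

Compound 2 holds the higher of the two numbers shown, yet the step of a 1.4-fold lower number from compound 2 to compound 3 (0.15 log units; within the scatter) is within the scatter, so no real order follows. Compound 4 `CCOc1ccc(-c2ccc3ncn(-c4cc(OC)c(OC)c(OC)c4)c3c2)cc1` differs from compound 2 by 4-ethoxyphenyl in place of 2-methoxyphenyl on an aromatic carbon. Going by the values given here, the only measured step at this position, a 1.4-fold lower number from compound 2 to compound 3 (0.15 log units; within the scatter), stayed within the scatter, and no compound here carries an ethoxy, so the data give little to lean on. The step of a 1.1-fold lower number from compound 2 to compound 4 (0.03 log units; within the scatter) is therefore expected to remain within the scatter. Compound 4 is estimated at 4000 nM, with a range from 1500 nM to 12000 nM.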

Compound 4, half-maximal inhibitory concentration: 8550 nM
Estimate against measurement, compound 4: 2.1-fold (0.33 log units) below; measured number inside the range.
By their numbers in this assay, from the lowest: compounds 3, 2 and 4 (each within the scatter of the next, the first and the last beyond it). At a limit, above all of these: compound 1.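

Ethoxy in place of hydrogen shows a 2.8-fold higher number from compound 3 to compound 4 (0.45 log units; beyond the scatter), the first step at this position that lies beyond the scatter in this assay, and it points toward weaker inhibition. Putting 4-ethoxyphenyl in place of 2-methoxyphenyl gives a 2.0-fold higher number from compound 2 to compound 4 (0.30 log units; within the scatter), so these two compounds cannot be ordered. Nothing shown gives a cause for either step.

Still open, from the compounds shown here alone, is whether the group or its place on the ring counts more, which a 4-methoxyphenyl would help to separate. Going by these compounds, how an amine or a carboxylic acid would read at this position is also open.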